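The compounds below may be only part of what the source reports. "The series", "measured", "known", "first", "only" and "open" are said of these compounds alone.

Compound 1, `CCC(=O)c1ccc(NCc2cncn2Cc2ccc(-c3ccccc3)cc2)cc1-c1ccccc1`: in a toxicity assay on NIH3T3 cells (Mus musculus) for cytotoxicity, read by resazurin assay (a higher number here means that more compound is needed for the effect, a lower number that less compound is needed), compound 1 gives > 10000 nM, which is a limit of the assay and not a number.
Compound 2, `CCCC(=O)c1ccc(NCc2cncn2Cc2ccc(-c3ccccc3)cc2)cc1-c1ccccc1`: in this assay compound 2 gives > 10000 nM, again a limit and not a number.

The change from compound 1 to compound 2 is methyl in place of hydrogen on a saturated chain carbon, two bonds along the chain from a carbonyl carbon, and because both values are limits the step that the two limits leave unreadable from compound 1 to compound 2 cannot be read. Compound 2 thus stands at the limit of > 10000 nM in this assay, at which 2 of the 2 values shown sit, with no number of its own.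

Compound 3, `CN(C)c1ccc(NCc2cncn2Cc2ccc(-c3ccccc3)cc2)cc1-c1ccccc1`, differs from compound 2 by dimethylamino in place of propylcarbonyl on an aromatic carbon. Among the compounds with values here, no measured step bears on this change, and the one step that was measured is itself unreadable, so there is nothing in the numbers that points in either direction. Compound 3 is therefore expected to stay near the limit in this assay, with an estimate of 15000 nM and a range from 4000 nM to 60000 nM. The step this estimate implies is a step that the limit leaves unreadable from compound 2 to compound 3, expected to be nothing beyond the scatter.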

Compound 3, half-maximal effective concentration: > 1000 nM
Compound 3 ended at the assay's limit (the forecaster's own chance of this, stated with the estimate: 70%); the middle value is on the limit's open side.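

In this assay compound 3 gives > 1000 nM, which is a limit of the assay and not a number. Within the data shown here, compound 1 and compound 2 also stand at limits, so no step among compound 1, compound 2 and compound 3 can be read. The compounds shown leave open whether dimethylamino in place of propylcarbonyl changes the result in this assay at all.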